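The source may report more compounds than this note shows. Statements on the series, on what has been measured and on what is new or still open speak of the compounds shown alone.

Measured so far:
- compound 1 `O=C1C(=Cc2ccc(O)cc2)C(=O)N(c2ccc(Cl)cc2)N1c1ccc(Cl)cc1` gives 34200 nM in a functional assay on ECa-109 cells (Homo sapiens) for cytotoxicity, read by MTT assay, with a stated time of 72 h; a higher number here means a weaker inhibitor, a lower number a stronger inhibitor
- compound 2 `O=C1C(=Cc2ccco2)C(=O)N(c2ccc(Cl)cc2)N1c1ccc(Cl)cc1` gives 14300 nM in this assay

Compound 2, at 14300 nM in this assay, holds the lower of the two numbers. Compound 3 `O=C1C(=C/C=C/c2ccccc2)C(=O)N(c2ccc(Cl)cc2)N1c1ccc(Cl)cc1` carries the change 2-phenylethenyl in place of furan-2-yl on a double-bonded chain carbon bound to a double-bonded ring carbon with 2-phenylethenyl in place of furan-2-yl on a double-bonded chain carbon bound to a double-bonded ring carbon. For the measured compounds named here, one measured step bears on it, at the same place: a 2.4-fold lower number from compound 1 to compound 2 (0.38 log units; beyond the scatter) in this assay, a modest change. Going by the values given here, no measured compound holds 2-phenylethenyl, so the data do not settle a direction. A step within the scatter is therefore expected, leaning slightly to a lower number. The estimate is a 1.2-fold lower number from compound 2 to compound 3 (0.08 log units; within the scatter) in size and direction. For compound 3 the estimated value in this assay is 12000 nM with an expected range from 4500 nM to 35000 nM on repeat measurement.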

Compound 3, half-maximal inhibitory concentration: 9900 nM
Compound 3: middle estimate off by 1.2-fold (0.08 log units), on the high side; the range from low to high includes it.
By their numbers in this assay, from the lowest: compounds 3 and 2 (each within the scatter of the next); then compound 1.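

At the double-bonded chain carbon bound to a double-bonded ring carbon, replacing furan-2-yl with 2-phenylethenyl does not separate the two compounds in this assay, since a 1.4-fold lower number from compound 2 to compound 3 (0.16 log units; within the scatter) stays within the scatter. Compound 1 now stands apart from two different groups at this place: a 3.5-fold lower number from compound 1 to compound 3 (0.54 log units; beyond the scatter) adds a second step beyond the scatter, so among these three compounds, 4-hydroxyphenyl gives the highest number, and furan-2-yl and 2-phenylethenyl cannot be ranked against each other. No supporting data are available to explain these differences.

Going by these compounds, whether a longer chain, such as 4-phenylbuta-1,3-dien-1-yl, or a phenyl ring carrying an amine or a carboxylic acid would move the number further at this place remains open. The shown compounds also leave open whether any change to the two 4-chlorophenyl groups would shift the number.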